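The source may report more compounds than this note shows. Statements on the series, on what has been measured and on what is new or still open speak of the compounds shown alone.

Compound 1 `N#Cc1cccc(COc2ccc(-c3cc(CN4CCN(Cc5ccc(C(F)(F)F)cc5)CC4)no3)cc2)c1`, compound 2 `N#Cc1cccc(COc2ccc(-c3cc(CN4CCN(c5ccc(C(F)(F)F)cn5)CC4)no3)cc2)c1` and compound 3 `N#Cc1cccc(COc2ccc(-c3cc(CN4CCN(Cc5ccc(F)cc5)CC4)no3)cc2)c1` share one core and differ only in the group on the ring nitrogen. In a functional assay on MCF7 cells (Homo sapiens) for antiproliferative activity, read by sulforhodamine B assay, with a stated time of 72 h (on this read-out lower numbers stand for stronger inhibition and higher numbers for weaker inhibition), compound 1 gives 800 nM, compound 2 gives 1400 nM and compound 3 gives 1800 nM. Among the measured compounds shown here, compound 3 thus carries the highest number of the three; its gap to compound 2 is within the scatter, while the change a 2.3-fold higher number from compound 1 to compound 3 (0.35 log units; beyond the scatter) is the only step here that goes beyond it. The remaining steps, a 1.8-fold higher number from compound 1 to compound 2 (0.24 log units; within the scatter) and a 1.3-fold higher number from compound 2 to compound 3 (0.11 log units; within the scatter), are both within the scatter. Compound 4 `N#Cc1cccc(COc2ccc(-c3cc(CN4CCN(Cc5ccccc5F)CC4)no3)cc2)c1` is the unmeasured partner of compound 3; the change is 2-fluorophenyl in place of 4-fluorophenyl on a saturated chain carbon bound to an amine nitrogen in a ring. For the measured compounds named here, no measured step moves a fluorine around a ring, so nothing bears on this change directly; the closest guide is how little the group on the ring nitrogen has shifted the numbers across compounds 1, 2 and 3. The step of no change at the digits printed from compound 3 to compound 4 (within the scatter) is therefore expected to stay within the scatter, with no clear direction. The estimate for compound 4 in this assay is 1800 nM, between 900 nM and 3600 nM.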

Compound 4, half-maximal inhibitory concentration: 1400 nM
The estimate for compound 4 lay 1.3-fold (0.11 log units) above the measured number; low and high end bracket the measured number.
By their numbers in this assay, from the lowest: compounds 1, 2, 4 and 3 (each within the scatter of the next, the first and the last beyond it).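

In this assay, among the compounds shown here, the step of a 1.3-fold lower number from compound 3 to compound 4 (0.11 log units; within the scatter) gives the first reading of where the fluorine sits on the benzyl group, and at this resolution 2-fluorophenyl and 4-fluorophenyl are not told apart. The 2-fluorobenzyl group also stays level with the other groups on the ring nitrogen, with no change at the digits printed from compound 2 to compound 4 (within the scatter) and a 1.8-fold higher number from compound 1 to compound 4 (0.24 log units; within the scatter), so unlike compound 3, compound 4 is not separated from compound 1. No measurement at hand offers an explanation for these numbers. The compounds shown leave open whether 3-fluorobenzyl, unsubstituted benzyl or 2-(trifluoromethyl)benzyl on the ring nitrogen would separate from this group of values. They also leave open whether the two fluorobenzyl compounds would stay together on any other cell line.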